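The compounds below may be only part of what the source reports. "The series", "measured", "known", "first", "only" and "open" are said of these compounds alone.

Compound 1 `Nc1scc(CN2CCN(c3cccc(Cl)c3Cl)CC2)c1C(=O)c1ccc(Cl)cc1`: 2%
Compound 2 `Nc1scc(CN2CCN(c3ccc(Cl)cc3F)CC2)c1C(=O)c1ccc(Cl)cc1`: 0%
Compound 3 `Nc1scc(CN2CCN(c3cccnc3)CC2)c1C(=O)c1ccc(Cl)cc1`: 0%

In an assay on CHO cells for displacement of a labelled ligand from adenosine receptor A1 (Homo sapiens), read by scintillation counting, with a stated time of 120 min, tested at 10 uM (on this read-out lower numbers stand for less inhibition and higher numbers for more inhibition at the one concentration tested (going by the name of the read-out)), compound 3 stands level with compound 2 at the digits shown, the two together the lowest of the three numbers, and compound 1 sits only a hair apart: the recorded steps a number 2 percentage points lower from compound 1 to compound 3 (within the scatter) and no change at the digits printed from compound 2 to compound 3 (within the scatter) both lie within the scatter. Compound 4 `Nc1scc(CN2CCN(c3cc(F)cc(F)c3)CC2)c1C(=O)c1ccc(Cl)cc1` differs from compound 3 by 3,5-difluorophenyl in place of pyridin-3-yl on an amine nitrogen in a ring. Every measured step bears on this kind of change, since each swaps the aromatic group on the amine nitrogen in the ring: a number 2 percentage points lower from compound 1 to compound 2 (within the scatter), a number 2 percentage points lower from compound 1 to compound 3 (within the scatter) and no change at the digits printed from compound 2 to compound 3 (within the scatter), all within the scatter. Compound 4 is therefore expected to show no step beyond the scatter, a number 1 percentage points higher from compound 3 to compound 4 (within the scatter). Compound 4 is estimated at 1%, within -8% to 10%.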

Compound 4, a percentage reported as inhibition, at one concentration (the size of the read-out at that concentration, not a potency): 0%
Estimate against measurement, compound 4: 1 percentage points above; measured number inside the range.
By their numbers in this assay, from the lowest: compounds 2, 3, 4 and 1 (each within the scatter of the next).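

On the amine nitrogen in the ring, 3,5-difluorophenyl in place of pyridin-3-yl exchanges a ring with a hetero atom for one of carbon only, yet this assay gives no change at the digits printed from compound 3 to compound 4 (within the scatter). The other two steps to this group read alike, no change at the digits printed from compound 2 to compound 4 (within the scatter) and a number 2 percentage points lower from compound 1 to compound 4 (within the scatter), so a ring carrying only fluorine joins the earlier aromatic groups with no step beyond the scatter. Nothing at hand accounts for this reading. The compounds shown leave open whether a non-aromatic group at this place, such as cyclohexyl, or an aromatic ring carrying a carboxylic acid or an amine, would move the number beyond the scatter.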